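Removing a methyl from a weak chlorinated acid

This account rests on a few compounds, and the source may have more. Where it says the series, first, only, none or still open, it means among the compounds named here.

Measured so far, in a functional assay on HL-60 cells (Homo sapiens) for antiproliferative activity, with a stated time of 72 h; a higher number here means a weaker inhibitor of growth, a lower number a stronger inhibitor of growth:
compound 1 `C=C(CCC)C(=O)c1ccc(OC(C)C(=O)OC)c(C)c1C` gives 5600 nM.
compound 3 `C=C(CC)C(=O)c1ccc(OC(C)C(=O)OC)c(C)c1C` gives 4600 nM.
compound 2 `C=C(C)C(=O)c1ccc(OC(C)C(=O)O)cc1Cl` gives only a limit, > 60000 nM.

Compound 1 and compound 3 share a core and differ by hydrogen in place of methyl on a saturated chain carbon, two bonds along the chain from a double-bonded chain carbon, a step of a 1.2-fold lower number from compound 1 to compound 3 (0.09 log units; within the scatter). Compound 2 has a different core; the difference between the two cores is not broken down here, and compound 2 sits at the limit of > 60000 nM in this assay, at which 1 of the 3 values shown sits.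

Compound 4 `C=C(C)C(=O)c1ccc(OCC(=O)O)cc1Cl` is not yet measured. It differs from compound 2 by hydrogen in place of methyl on a saturated chain carbon bound to a carbonyl carbon and an oxygen on an aromatic ring. This is the same kind of change as from compound 1 to compound 3, but at a different place: there the methyl left a saturated chain carbon two bonds along the chain from a double-bonded chain carbon, here it leaves a saturated chain carbon bound to a carbonyl carbon and an oxygen on an aromatic ring. Because a 1.2-fold lower number from compound 1 to compound 3 (0.09 log units; within the scatter) stayed within the scatter, the step is expected to be a step that the limit leaves unreadable from compound 2 to compound 4. Compound 4 is therefore expected near 80000 nM, most likely again as a limit.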

Compound 4, concentration for 50% growth inhibition: > 60000 nM
Compound 4: only a limit was reported; the forecaster's own chance of this, stated with the estimate: 75%; the middle value is on the limit's open side.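

In this assay compound 4 gives > 60000 nM, a limit and not a number. Among these compounds, compound 2 also gives a limit, > 60000 nM, so no step between the two can be read. Going by these compounds, whether swapping this methyl for hydrogen changes growth inhibition in these acids stays open.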